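Fluoro Addition on Two Cores Tested for Antiproliferative Effect

The source may hold more compounds than are shown below. What is called first, only, known or untested is meant among the compounds shown, and "the series" means these compounds.

This account follows four compounds that share a common heterocyclic core and were, or are to be, measured in a functional assay on ME-180 cells (Homo sapiens) for antiproliferative activity, read by MTT assay; on this read-out higher numbers stand for weaker inhibition and lower numbers for stronger inhibition. Compound 1 `Cc1nn2c(-c3nc4ccccc4[nH]3)c(-c3ccccc3)nc2s1` gives 16900 nM in this assay. Compound 3 `Cc1nn2c(-c3nc4ccccc4[nH]3)c(-c3ccc(F)cc3)nc2s1` carries the change fluoro in place of hydrogen on an aromatic carbon relative to compound 1. In this assay compound 3 gives 18100 nM, so that a 1.1-fold higher number from compound 1 to compound 3 (0.03 log units; within the scatter). For the measured compounds named here, compound 2 `Cc1ccc(-c2nc3sc(C)nn3c2-c2nc3cc(Cl)ccc3[nH]2)cc1` gives 3600 nM in this assay and stands lowest of the three numbers measured so far; the difference between its core and the core of compound 1 is not broken down here.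

Compound 4 `Cc1ccc(-c2nc3sc(C)nn3c2-c2nc3cc(Cl)c(F)cc3[nH]2)cc1` has not yet been measured. It differs from compound 2 by fluoro in place of hydrogen on an aromatic carbon. Going by the values given here, this is the same kind of change as the one from compound 1 to compound 3, but not the same: in compound 3 the fluoro sits on a six-membered aromatic ring of carbon only, para to a large group, whereas in compound 4 it sits on a ring that is part of a fused system of two rings, ortho to a chloro group, meta to a fused ring and para to a fused ring.

Among the compounds with values here, because the only measured instance of this kind of change, a 1.1-fold higher number from compound 1 to compound 3 (0.03 log units; within the scatter), stayed within the scatter, a similarly small step is expected from compound 2 to compound 4, namely a 1.1-fold lower number from compound 2 to compound 4 (0.04 log units; within the scatter). Compound 4 is therefore estimated at 3300 nM in this assay, with a range from 1400 nM to 8000 nM.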

Compound 4, half-maximal inhibitory concentration: 700 nM
Compound 4: middle estimate off by 4.7-fold (0.67 log units), on the high side, outside the stated range (below it).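

In this assay, fluoro in place of hydrogen on an aromatic carbon gives a 5.1-fold lower number from compound 2 to compound 4 (0.71 log units; beyond the scatter), so the change does not keep its size from one core to the other. The step measured on the core of compound 1 therefore gave no reliable guide to the step on the core of compound 2, and the two steps differ clearly: the same change on two cores in this assay, a 1.1-fold higher number (0.03 log units; within the scatter) from compound 1 to compound 3 and a 5.1-fold lower number (0.71 log units; beyond the scatter) from compound 2 to compound 4, 5.5-fold (0.74 log units) apart, beyond the scatter of two such steps. What this does not show is the source of the gap, since the two pairs differ both in their cores and in where the fluoro sits, on a ring of carbon only in compound 3 and on a ring that is part of a fused system, ortho to a chloro group, in compound 4, and two pairs cannot separate these.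

The compounds shown leave open whether fluoro on that fused ring would give a step of similar size without the chloro group, or on the core of compound 1. They also leave open whether a larger or differently built group at the same place, such as a methoxy group, an amine or a carboxylic acid, would move the number in the same direction as fluoro does in compound 4.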